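Changing the aryl group on the azo link

The compounds below may be only part of what the source reports. "The series", "measured", "known", "first", "only" and "open" are said of these compounds alone.

Three triazene-type compounds have been tested in an ADME assay on MT4 cells (Homo sapiens) for cytotoxicity, read by MTT assay, with a stated time of 96 h; on this read-out higher numbers stand for lower toxicity in this test and lower numbers for higher toxicity in this test. Compound 1, `Brc1cccc(/N=N/N2CCCCC2)c1`, gives only a limit of the assay, > 100000 nM. Compound 2, `FC(F)(F)c1cccc(/N=N/c2ccc(NC[C@@H]3CCCN4CCCC[C@H]34)c3c2CCCC3)c1`, gives 15000 nM in this assay. Compound 3, `CN(C)CCCN(/N=N/c1c(F)cccc1F)c1ccccc1`, gives 23000 nM in this assay, and the two numbers lie within the usual scatter of each other, so no order between compound 2 and compound 3 can be read from them. Of the two numbers shown, compound 2 carries the lower one, while compound 1 sits at the limit (the limit of > 100000 nM in this assay, at which 1 of the 3 values shown sits).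

The next compound, compound 4, is `Fc1ccc(/N=N/c2ccc(NC[C@@H]3CCCN4CCCC[C@H]34)c3c2CCCC3)c(F)c1`. It differs from compound 2 in one place: 2,4-difluorophenyl in place of 3-(trifluoromethyl)phenyl on a double-bonded nitrogen. No step between two measured compounds that differ only in this way has been measured, so nothing in the shown data tells how large a step to expect from this exchange. The expectation is therefore that compound 4 stays close to compound 2 in this assay, with no change beyond the scatter, which is a step from a 1.2-fold higher number from compound 2 to compound 4 (0.08 log units; within the scatter) that is expected to be small. For compound 4 the estimated value in this assay is 18000 nM, with a likely range from 7000 nM to 50000 nM.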

Compound 4, half-maximal cytotoxic concentration: 51000 nM
The estimate for compound 4 lay 2.8-fold (0.45 log units) below the measured number; the whole stated range lies below it.
By their numbers in this assay, from the lowest: compounds 2 and 3 (each within the scatter of the next); then compound 4. At a limit, above all of these: compound 1.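

Within the data shown here, this pair gives the first direct reading of a single change. With the shared core kept, 2,4-difluorophenyl in place of 3-(trifluoromethyl)phenyl on a double-bonded nitrogen gives a 3.4-fold higher number from compound 2 to compound 4 (0.53 log units; beyond the scatter) in this assay, a modest step that lies beyond the usual scatter of repeated measurements. The aryl group at this position therefore matters to the read-out, and since a higher number here stands for lower toxicity in this test, this exchange moves the compound in the less toxic direction, so the shared core alone does not set the value. Nothing among the data shown explains why this exchange moves the number.

The exchange removes the trifluoromethyl group and adds two fluorine atoms in a single move, so the pair cannot show which of these two parts accounts for the step, and a plain phenyl group at this position would be the natural point of comparison. Going by these compounds, it also remains open how the number would respond to an aryl group carrying an amine, a methoxy group or a carboxylic acid on this same double-bonded nitrogen.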